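The source may report more compounds than this note shows. Statements on the series, on what has been measured and on what is new or still open speak of the compounds shown alone.

In a functional assay on DU-145 cells (Homo sapiens) for cytotoxicity, read by trypan blue exclusion, with a stated time of 96 h (a lower number here means a stronger inhibitor, a higher number a weaker inhibitor), compound 1 `COc1cc(OC)c(/C=C/S(=O)(=O)Cc2ccc(OC)c([N+](=O)[O-])c2)c(OC)c1` gives 2500 nM, and compound 2 `COc1cc(OC)c(/C=C/S(=O)(=O)Cc2ccc(OC)c(NC(C)(C)C(=O)O)c2)c(OC)c1` gives 150 nM. Among the measured compounds shown here, compound 2 therefore holds the lower, more favourable number of the two measured so far. The next compound, compound 3 `COc1cc(OC)c(/C=C/S(=O)(=O)Cc2ccc(OC)c(NC(C(=O)O)c3ccc(F)cc3)c2)c(OC)c1`, has carboxy(4-fluorophenyl)methyl in place of 1-carboxy-1-methylethyl on a nitrogen on an aromatic ring. For the measured compounds named here, only one measured step bears on this change, and only indirectly. That large step, a 17-fold lower number from compound 1 to compound 2 (1.22 log units; beyond the scatter), came from putting (1-carboxy-1-methylethyl)amino in place of nitro. It shows that this part of the molecule can strongly affect the number in this assay, but it does not show what happens when the group on the nitrogen is altered. The carboxy group remains in compound 3, while a six-membered aromatic ring enters. Going by the values given here, with no measured precedent for this swap, neither direction can be favoured, so no step beyond the scatter is expected, though the uncertainty is wide. The expected step is a 1.3-fold higher number from compound 2 to compound 3 (0.12 log units; within the scatter). For compound 3, the estimated value is 200 nM, with an expected range from 50 nM to 900 nM.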

Compound 3, half-maximal inhibitory concentration: 150 nM
Compound 3: middle estimate off by 1.3-fold (0.12 log units), on the high side; the measured number falls inside the stated range.
By their numbers in this assay, from the lowest: compounds 2 and 3 (each within the scatter of the next); then compound 1.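

In this assay the group on the nitrogen can grow considerably without a measurable penalty: carboxy(4-fluorophenyl)methyl, with 11 heavy atoms and a six-membered aromatic ring, takes the place of 1-carboxy-1-methylethyl, with 6 heavy atoms and no ring, and the outcome is no change at the digits printed from compound 2 to compound 3 (within the scatter). The gain over the nitro compound is therefore not tied to 1-carboxy-1-methylethyl alone: a second group on the nitrogen, which also carries the carboxy group, gives a 17-fold lower number from compound 1 to compound 3 (1.22 log units; beyond the scatter). Nothing available gives a measured reason for this match between the two groups.

Both groups on the nitrogen carry a carboxylic acid, so the compounds shown leave open whether that acid matters, a question that a methyl ester, an amide or a plain amine in the same place could address. They also do not separate the part played by the fluorine from that of the aromatic ring, which an unsubstituted phenyl or a 4-methoxyphenyl group could help to resolve.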